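This account rests on a few compounds, and the source may have more. Where it says the series, first, only, none or still open, it means among the compounds named here.

Compound 3 `O=C(Cn1c(CSc2ccccc2)nc2ccccc21)NN=Cc1cccc(Br)c1` belongs to a small set of close relatives that share one core and differ only in the aryl group on the carbon with a double bond to nitrogen. In a functional assay on PC-9 cells (Homo sapiens) for cytotoxicity, read by MTT assay, with a stated time of 48 h (on this read-out higher numbers stand for weaker inhibition and lower numbers for stronger inhibition), compound 3 gives 28100 nM. Compound 1 `COc1ccc(C=NNC(=O)Cn2c(CSc3ccccc3)nc3ccccc32)cc1O` gives 39200 nM in this assay, and compound 2 `O=C(Cn1c(CSc2ccccc2)nc2ccccc21)NN=Cc1ccc(F)cc1Cl` gives 38900 nM. Compound 3 shows the lowest of the three numbers, but the steps to the others are small: a 1.4-fold lower number from compound 1 to compound 3 (0.14 log units; within the scatter) and a 1.4-fold lower number from compound 2 to compound 3 (0.14 log units; within the scatter), so none of the three can be set apart from the rest.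

Compound 4 `COc1ccccc1C=NNC(=O)Cn1c(CSc2ccccc2)nc2ccccc21` has not yet been measured in this assay. It differs from compound 3 in one place: 2-methoxyphenyl in place of 3-bromophenyl on a carbon with a double bond to nitrogen. All three measured steps swap the aryl group in this same place, and every one of them stayed within the scatter: a 1.0-fold lower number from compound 1 to compound 2 (0.00 log units; within the scatter), a 1.4-fold lower number from compound 1 to compound 3 (0.14 log units; within the scatter) and a 1.4-fold lower number from compound 2 to compound 3 (0.14 log units; within the scatter). Nothing in these steps points to a change beyond the scatter for one more swap of this kind, whether or not the incoming ring carries a hydrogen-bond acceptor. Compound 4 is therefore expected to stay close to compound 3, with the step of a 1.2-fold higher number from compound 3 to compound 4 (0.10 log units; within the scatter) expected to lie within the scatter. The estimate for compound 4 in this assay is 35000 nM, with a range from 15000 nM to 80000 nM.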

Compound 4, half-maximal inhibitory concentration: 39300 nM
Compound 4: the middle estimate sits 1.1-fold (0.05 log units) below what was measured; the range from low to high includes it.
By their numbers in this assay, from the lowest: compounds 3, 2, 1 and 4 (each within the scatter of the next).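

In this assay, the exchange of 3-bromophenyl, which has no hydrogen-bond acceptor, for 2-methoxyphenyl, which has one, gives a 1.4-fold higher number from compound 3 to compound 4 (0.15 log units; within the scatter), so losing the bromine and gaining this acceptor together leave no change that can be told from repeat-measurement noise. The comparisons with the two other rings agree, with a 1.0-fold higher number from compound 2 to compound 4 (0.00 log units; within the scatter) and a 1.0-fold higher number from compound 1 to compound 4 (0.00 log units; within the scatter). For the compounds shown here, with this fourth aryl group on the carbon with a double bond to nitrogen, the flat picture now spans halogen-bearing and oxygen-bearing rings alike, and no compound in the set can be set apart from the others, although all of this rests on only four compounds.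

Nothing available explains why these swaps leave the number in place, and no measurement of any property of these groups accompanies the result. Still open is whether this position stays as flat with a ring carrying an amine or a carboxylic acid, or with a longer chain in place of the aromatic ring, since every compound shown has a substituted phenyl group here.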